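The source may hold more compounds than are shown below. What is called first, only, known or untested is meant among the compounds shown, and "the series" means these compounds.

Measured so far in a functional assay on PC-3 cells (Homo sapiens) for inhibition, read by MTT assay, with a stated time of 72 h; on this read-out lower numbers stand for stronger inhibition and higher numbers for weaker inhibition:
compound 1 `O=C(CSc1nc(Nc2ccccc2)c2ccccc2n1)Nc1ccccc1F` gives 12400 nM
compound 2 `O=C(CSc1nc(Nc2ccccc2)c2ccccc2n1)Nc1ccc(Br)cc1` gives 8450 nM

Going by the values given here, only two compounds have numbers. Among the compounds with values here, compound 2 stands next to compound 1, the one step between them being a 1.5-fold lower number from compound 1 to compound 2 (0.17 log units; within the scatter), so the two are not separated beyond the scatter and neither can be placed above the other.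

Compound 3 `O=C(CSc1nc(Nc2ccccc2)c2ccccc2n1)Nc1ccc(C(F)(F)F)cc1` is not yet measured. It differs from compound 2 by trifluoromethyl in place of bromo on an aromatic carbon, a change on the same aromatic ring that already carries the variation between compound 1 and compound 2. That single measured step bears on it only loosely, and it was small. Nothing in the series marks out a large effect for a swap of this kind, so the expected step of a 1.1-fold lower number from compound 2 to compound 3 (0.02 log units; within the scatter) from compound 2 to compound 3 is one that stays within the scatter. Compound 3 is therefore estimated at 8000 nM in this assay, with a range from 3500 nM to 18000 nM.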

Compound 3, half-maximal inhibitory concentration: 10400 nM
Beside the measured number, compound 3's estimate is 1.3-fold (0.11 log units) below it; the measured number falls inside the stated range.
By their numbers in this assay, from the lowest: compounds 2, 3 and 1 (each within the scatter of the next).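

In this assay, the aromatic carbon para to a large group takes trifluoromethyl, with 4 heavy atoms, in place of bromo, with 1, and the reading stays within the scatter (a 1.2-fold higher number from compound 2 to compound 3 (0.09 log units; within the scatter)). The comparison of the two amide substituents 4-(trifluoromethyl)phenyl and 2-fluorophenyl is also within the scatter (a 1.2-fold lower number from compound 1 to compound 3 (0.08 log units; within the scatter)), so the three aryl groups on the amide nitrogen of compounds 1, 2 and 3 are not separated from one another in this small set. No available evidence bears on this result.

Going by these compounds, whether an amine or a carboxylic acid at this same aromatic carbon would give a step beyond the scatter remains open. Also open, on these data alone, is the effect of a longer chain between the sulfur and the amide carbonyl.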